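The source may report more compounds than this note shows. Statements on the series, on what has been measured and on what is new or still open speak of the compounds shown alone.

In a functional assay on U-251 cells (Homo sapiens) (a higher number here means a weaker inhibitor of growth, a lower number a stronger inhibitor of growth), three compounds sharing one core have been measured. Compound 1 `O=S(=O)(/C=C/c1ccccc1)Cc1ccc(Nc2ncnc3ccccc23)cc1`, with a plain phenyl, gives > 100000 nM, which is a limit of the assay and not a number. Compound 2 `O=S(=O)(/C=C/c1ccc(Cl)cc1Cl)Cc1ccc(Nc2ncnc3ccccc23)cc1` gives 4000 nM, and compound 3 `O=S(=O)(/C=C/c1ccc(C(F)(F)F)cc1F)Cc1ccc(Nc2ncnc3ccccc23)cc1` gives 100000 nM, so compound 2 holds the lower of the two actual numbers.

Compound 4 `O=S(=O)(/C=C/c1ccc(Cl)cc1Cl)Cc1ccc(Nc2ncnc3cc(Cl)ccc23)cc1` differs from compound 2 by one change, chloro in place of hydrogen on an aromatic carbon of the fused system of two rings.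

The measured steps all alter the phenyl group on the double-bonded chain, not this ring. From the compounds shown here alone, two were large, an at least 25-fold lower number from compound 1 to compound 2 (1.39 log units; beyond the scatter) and a 25-fold higher number from compound 2 to compound 3 (1.40 log units; beyond the scatter), while the size of a number no higher from compound 1 to compound 3 (the limit leaves the size open) stays open. They show that the number can move strongly within this small set, but none tests the new place, so they give no direction for it. The expected change is therefore none beyond the scatter, a 1.3-fold lower number from compound 2 to compound 4 (0.12 log units; within the scatter), though with wide uncertainty. For compound 4 the estimate is 3000 nM, with an expected range of 600 nM to 20000 nM.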

Compound 4, concentration for 50% growth inhibition: 53000 nM
The estimate for compound 4 lay 18-fold (1.25 log units) below the measured number; the measured number lies above the stated range.
By their numbers in this assay, from the lowest: compound 2; then compounds 4 and 3 (each within the scatter of the next).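

Adding a single chloro on an aromatic carbon of the fused system of two rings weakens growth inhibition in this assay by a wide margin: the step is a 13-fold higher number from compound 2 to compound 4 (1.12 log units; beyond the scatter) and it is the first test of this ring. So the number responds strongly to this part of the shared core, and not only to the phenyl group on the double-bonded chain, and between these two compounds hydrogen is the better choice at this place. This rests on a single pair, and nothing measured here explains the rise.

From the compounds shown here alone, it remains open whether a fluoro, a methoxy or an amine on the same carbon would cost as much as chloro. Also open, going by these compounds, is whether chloro there would have a similar effect with the phenyl groups of compound 1 and compound 3.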